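From 2-Fluorophenyl to 3-Nitrophenyl on the Amide Nitrogen

The source may hold more compounds than are shown below. What is called first, only, known or untested is meant among the compounds shown, and "the series" means these compounds.

Measured compounds:
compound 1 `O=C(CSc1nc(Nc2ccccc2)c2ccccc2n1)Nc1ccccc1F` — 9350 nM
compound 2 `O=C(CSc1nc(Nc2ccccc2)c2ccccc2n1)Nc1cccc(F)c1` — 6790 nM

Compound 1 gives the highest of the two numbers in a functional assay on NCI-H1975 cells (Homo sapiens) for inhibition, read by MTT assay, with a stated time of 72 h (a lower number here means a stronger inhibitor, a higher number a weaker inhibitor), but its nearest neighbour is compound 2, and the step of a 1.4-fold lower number from compound 1 to compound 2 (0.14 log units; within the scatter) sits within the scatter, so the two compounds cannot be ranked against each other on these data.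

Compound 3 `O=C(CSc1nc(Nc2ccccc2)c2ccccc2n1)Nc1cccc([N+](=O)[O-])c1` has not yet been measured in this assay. It differs from compound 1 by 3-nitrophenyl in place of 2-fluorophenyl on an amide-type nitrogen. Among the measured compounds shown here, the only measured step, a 1.4-fold lower number from compound 1 to compound 2 (0.14 log units; within the scatter), concerns the same amide nitrogen but moves only a fluorine on the ring, and no step involving a nitrophenyl group has been measured. The available data therefore give no ground to expect a shift beyond the scatter in either direction.

For compound 3 the estimate is 8000 nM in this assay, spanning 3000 nM to 25000 nM, which corresponds to an expected step of a 1.2-fold lower number from compound 1 to compound 3 (0.07 log units; within the scatter).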

Compound 3, half-maximal inhibitory concentration: 17900 nM
The estimate for compound 3 lay 2.2-fold (0.35 log units) below the measured number; measured number inside the range.
By their numbers in this assay, from the lowest: compounds 2, 1 and 3 (each within the scatter of the next, the first and the last beyond it).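

In this assay, the change at the amide-type nitrogen now yields a step that clears the scatter: a 2.6-fold higher number from compound 2 to compound 3 (0.42 log units; beyond the scatter) comes with nitro in place of fluoro on an aromatic carbon, though the step is modest. The other step, a 1.9-fold higher number from compound 1 to compound 3 (0.28 log units; within the scatter) with 3-nitrophenyl in place of 2-fluorophenyl, stays within the scatter, so this substituent change separates compound 3 from compound 2 but not from compound 1. No evidence is available to explain this difference.

The compounds shown leave open whether an unsubstituted phenyl, a 3-aminophenyl or a 3-carboxyphenyl group on this nitrogen would give numbers apart from these. They also leave open how a nitro group would read as 2-nitrophenyl, the direct counterpart of compound 1.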